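Watching One Side Chain Change in a Small Series

A few compounds are considered here, and "the series" means these few. Any claim that something is new, unique, unknown or untested is made for them only; others in the source may bear on it.

Compound 1 `C/C(=N/c1ccnc2cc(Cl)ccc12)NCCCCN1CCCCC1`: 9.81 ug/mL
Compound 2 `CC(C)/C(=N/c1ccnc2cc(Cl)ccc12)NCCCCN1CCCCC1`: 5.72 ug/mL
Compound 3 `CC(C)/C(=N/c1ccnc2cc(Cl)ccc12)NC1CCN(Cc2ccccc2)CC1`: 5.15 ug/mL

In an ADME assay on HepG2 cells (Homo sapiens) for cytotoxicity, read by MTT assay, with a stated time of 48 h (a lower number here means a stronger inhibitor, a higher number a weaker inhibitor), compound 2 gives 5.72 ug/mL. This lies nearest to compound 3 at 5.15 ug/mL and furthest from compound 1 at 9.81 ug/mL, and both gaps are within the usual scatter.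

Compound 4 `CCN(CC)CCN/C(=N\c1ccnc2cc(Cl)ccc12)C(C)C` carries diethylamino in place of 2-(piperidin-1-yl)ethyl on a saturated chain carbon, two bonds along the chain from an amine nitrogen.

Among the measured compounds shown here, no measured step makes this exact change. For the measured compounds named here, the only measured step, a 1.7-fold lower number from compound 1 to compound 2 (0.23 log units; within the scatter), concerns a different part of the molecule and stays within the scatter. The side chain also differs between compound 2 and compound 3, yet compound 3 at 5.15 ug/mL stays within the scatter of compound 2. On this thin evidence, no change beyond the scatter is expected in this assay. The expected size is a 1.1-fold higher number from compound 2 to compound 4 (0.06 log units; within the scatter). For compound 4 the estimated value is 6.5 ug/mL, with an expected range from 3 ug/mL to 14 ug/mL.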

Compound 4, half-maximal inhibitory concentration: 12.7 ug/mL
For compound 4 the middle estimate is 2.0-fold (0.29 log units) below the measured one; measured number inside the range.
By their numbers in this assay, from the lowest: compounds 3, 2, 1 and 4 (each within the scatter of the next, the first and the last beyond it).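

In this assay, putting diethylamino in place of 2-(piperidin-1-yl)ethyl on a saturated chain carbon, two bonds along the chain from an amine nitrogen, gives a 2.2-fold higher number from compound 2 to compound 4 (0.35 log units; beyond the scatter) and so a modest but real loss of inhibition. Among the compounds shown here, this is the first step to pass beyond the scatter, which shows that the assay can respond to a change at this position, as the step from methyl to isopropyl did not. The change removes the ring and lowers the heavy-atom count while leaving the donor and acceptor counts the same, but no measurement here explains the shift.

From the compounds shown here alone, whether the loss of the ring or the smaller group matters more remains open. A pyrrolidin-1-yl or morpholin-4-yl group at this position would help separate those two differences.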